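Dropping an Ethyl from the Fused Aromatic Ring

A few compounds are considered here, and "the series" means these few. Any claim that something is new, unique, unknown or untested is made for them only; others in the source may bear on it.

Compound 1 `CCc1ccc2c(c1)S/C(=c1/s/c(=C\c3ccncc3Nc3ccccc3F)n(CC)c1=O)N2C` stands at the weaker end of the two compounds tested in a functional assay on MCF7 cells (Homo sapiens) for inhibition (a lower number here means a stronger inhibitor, a higher number a weaker inhibitor), where compound 1 gives 1200 nM. Compound 2 `CCn1c(=O)/c(=C2\Sc3ccc(OC)cc3N2C)s/c1=C\c1ccncc1Nc1ccccc1C` gives 420 nM in this assay, a lower number than that of compound 1. Compound 3 `CCn1c(=O)/c(=C2\Sc3ccccc3N2C)s/c1=C\c1ccncc1Nc1ccccc1F` follows from compound 1 by hydrogen in place of ethyl on an aromatic carbon. Among the compounds with values here, no measured pair covers this change, so the expectation rests on the change alone: a small loss of potency, if any, is expected, as a 1.3-fold higher number from compound 1 to compound 3 (0.12 log units; within the scatter). Compound 3 is therefore estimated at 1600 nM, within 600 nM to 4500 nM.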

Compound 3, half-maximal inhibitory concentration: 330 nM
Compound 3: middle estimate off by 4.8-fold (0.69 log units), on the high side, and the stated range ends above it.
By their numbers in this assay, from the lowest: compounds 3 and 2 (each within the scatter of the next); then compound 1.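

In this assay, hydrogen in place of ethyl on an aromatic carbon gives a 3.6-fold lower number from compound 1 to compound 3 (0.56 log units; beyond the scatter), a step beyond the scatter. This first matched pair shows that this position affects the read-out and that, between these two groups, compound 3 with hydrogen is the stronger inhibitor. Nothing measured here explains the step. Still open, going by these compounds, is whether a chlorine atom, an amine or a longer chain on this aromatic carbon would behave like the ethyl. Also open, on these data alone, is whether the step holds when the rest of the molecule changes.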